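A few compounds are considered here, and "the series" means these few. Any claim that something is new, unique, unknown or untested is made for them only; others in the source may bear on it.

Two compounds of the series carry a value in an ADME assay on BaF3 cells (Mus musculus) for cytotoxicity; a higher number here means that more compound is needed for the effect, a lower number that less compound is needed. Compound 1 `FC(F)(F)Oc1ccc(Nc2ncnc3c2cnn3C2CCCCC2)cc1` gives 9300 nM there. Compound 2 `FC(F)(F)Oc1ccc(Nc2cc(-n3ccnc3)ncn2)cc1` reaches only a limit of this assay, > 10000 nM, so for compound 2 no number is known; this is the position marked by the limit of > 10000 nM in this assay, at which 1 of the 2 values shown sits. For the measured compounds named here, no step between measured compounds is available, and the pair shows only that compound 1 has a number while compound 2 has a limit.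

Compound 3 `FC(F)(F)Oc1ccc(Nc2cc(-c3ccnc4[nH]ccc34)ncn2)cc1` is still to be measured in this assay. It differs from compound 2 by a group of 9 heavy atoms (7 carbon, 2 nitrogen; one five-membered aromatic ring with 1 hetero atom, one six-membered aromatic ring with 1 hetero atom) in place of a group of 5 heavy atoms (3 carbon, 2 nitrogen; one five-membered aromatic ring with 2 hetero atoms), on an aromatic carbon. With compound 2 fixed only by a limit, the size of this step cannot be read from any measured pair. The expectation for compound 3 is a moderate step downward from the limit of compound 2, toward the value of compound 1, that is an at least 2.0-fold lower number from compound 2 to compound 3 (0.30 log units; that floor lies within the scatter), with a fair chance that this assay again reports only a limit. Compound 3 is thus expected at 5000 nM, between 1500 nM and 20000 nM.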

Compound 3, half-maximal effective concentration: 6850 nM
Compound 3: middle estimate off by 1.4-fold (0.14 log units), on the low side; low and high end bracket the measured number.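

In this assay, putting the two-ring group in place of 1H-imidazol-1-yl on the aromatic carbon gives an at least 1.4-fold lower number from compound 2 to compound 3 (0.16 log units; that floor lies within the scatter). Compound 3 gives 6850 nM, so a group at this place on the shared core can bring a measured number within the range of this assay. The value of compound 2 is a limit, and the step can be stated only as a floor because of it: the limit of > 10000 nM in this assay, at which 1 of the 3 values shown sits.

Going by these compounds, the true size of the step stays open, as does whether it follows the added ring or the hydrogen-bond donor, which change together in this single pair. Also open, on these data alone, is how the read-out responds at this place to a group without a second ring, such as a simple amine or a morpholine.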